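The source may hold more compounds than are shown below. What is called first, only, known or untested is meant among the compounds shown, and "the series" means these compounds.

Compound 1 `CCOC(=O)C1=C(C)N(c2ccc(C)cc2)C=CC1c1ccccc1`: -23.5%
Compound 2 `CCOC(=O)C1=C(C)N(c2ccc(F)cc2)C=CC1c1ccccc1`: -28.5%
Compound 3 `CCOC(=O)C1=C(C)N(c2ccc(Cl)cc2)C=CC1c1ccccc1`: -25.5%

These three share one core and differ only in the group on an aromatic carbon. In a functional assay for inhibition, using microsomes, tested at 100 ug/mL (a lower number here means a stronger effect, a higher number a weaker effect of the compound at the concentration tested), compound 3 gives -25.5%, the second highest of the three numbers; the steps of a number 2 percentage points lower from compound 1 to compound 3 (within the scatter) and a number 3 percentage points higher from compound 2 to compound 3 (within the scatter) are both within the scatter, so the three cannot be told apart. Compound 4 `CC1=C(C(=O)OC(C)(C)C)C(c2ccccc2)C=CN1c1ccc(Cl)cc1` differs from compound 3 by tert-butyl in place of ethyl on an oxygen next to a carbonyl group. Among the measured compounds shown here, no measured step touches this place: all three measured compounds carry the ethyl, and the measured steps change only the aromatic substituent. The expectation therefore rests on compound 3 alone. Compound 4 is expected to give about -25% in this assay, between -45% and -5%. The expected step is a number 0.5 percentage points higher from compound 3 to compound 4 (within the scatter), not beyond the scatter.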

Compound 4, a percentage reported as activity, at one concentration (the size of the read-out at that concentration, not a potency): -18.5%
The estimate for compound 4 lay 6.5 percentage points below the measured number; the range from low to high includes it.
By their numbers in this assay, from the lowest: compounds 2, 3, 1 and 4 (each within the scatter of the next).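

Putting tert-butyl in place of ethyl on an oxygen next to a carbonyl group, the first change shown at this place, gives a number 7 percentage points higher from compound 3 to compound 4 (within the scatter) in this assay. So this place accepts tert-butyl without a change that can be read, and all four compounds remain indistinguishable. No measurement is available that bears on this result.

Going by these compounds, whether a longer chain on this oxygen, or a free carboxylic acid or an amide at this place, would also stay within the scatter remains open. On these data alone, it is also open whether tert-butyl behaves the same with fluoro or methyl on the aromatic ring.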